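Shortening the thioether and swapping sulfur for oxygen

The source may hold more compounds than are shown below. What is called first, only, known or untested is meant among the compounds shown, and "the series" means these compounds.

Compound 1: `CSc1nc(=O)ccn1[C@@H]1O[C@H](COP(=O)(O)OP(=O)(O)O)[C@@H](O)[C@H]1O` — 4700 nM
Compound 2: `CCCSc1nc(=O)ccn1[C@@H]1O[C@H](COP(=O)(O)OP(=O)(O)O)[C@@H](O)[C@H]1O` — >= 100000 nM

In an in vitro functional assay on 1321-N1 cells for agonist activity at P2Y purinoceptor 6 (Homo sapiens), read by scintillation proximity assay and inositol phosphate accumulation (a higher number here means that more compound is needed for the effect, a lower number that less compound is needed), compound 1 gives 4700 nM. For compound 2 the assay reports only a limit, >= 100000 nM, so its position is known only as the limit of >= 100000 nM in this assay, at which 1 of the 2 values shown sits. Within the data shown here, the step of an at least 21-fold higher number from compound 1 to compound 2 (1.32 log units; beyond the scatter) is the sole measured comparison in this set. Compound 3, `COc1nc(=O)ccn1[C@@H]1O[C@H](COP(=O)(O)OP(=O)(O)O)[C@@H](O)[C@H]1O`, differs from compound 2 by methoxy in place of propylsulfanyl on an aromatic carbon. The measured step runs the other way in size: lengthening the chain moved the number far upward, so removing that length is expected to move it downward, though no measurement tells how a methoxy compares with a methylsulfanyl group. Compound 3 is therefore expected to land somewhat above compound 1, and the step of an at least 8.3-fold lower number from compound 2 to compound 3 (0.92 log units; beyond the scatter) is the estimate that follows. The estimate for compound 3 is 12000 nM, between 2500 nM and 100000 nM.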

Compound 3, half-maximal effective concentration: 1370 nM
Compound 3: middle estimate off by 8.8-fold (0.94 log units), on the high side; the measured number lies below the stated range.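

The new compound shows that the atom joining the group to the aromatic carbon between two ring nitrogen atoms matters, and not only the length of the chain: methoxy in place of methylsulfanyl gives a 3.4-fold lower number from compound 1 to compound 3 (0.54 log units; beyond the scatter) in this assay. Set against the propylsulfanyl compound, the change gives an at least 72-fold lower number from compound 2 to compound 3 (1.86 log units; beyond the scatter), so this position accepts methoxy far better than propylsulfanyl. Compound 2 is known only as a limit, which makes that step a bound and not an exact size: the limit of >= 100000 nM in this assay, at which 1 of the 3 values shown sits.

As far as these compounds go, the swap of sulfur for oxygen is read only on the methoxy and methylsulfanyl pair, so whether a longer chain on oxygen, such as propoxy, would raise the number as propylsulfanyl does stays open. From the compounds shown here alone, how an amine on this carbon would compare with methoxy also remains unknown.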